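The compounds below may be only part of what the source reports. "The series", "measured", "known", "first", "only" and "open" are said of these compounds alone.

Two compounds with a shared core have measured numbers in a functional assay on HL-60 cells (Homo sapiens) for antiproliferative activity, read by MTT assay; a higher number here means a weaker inhibitor, a lower number a stronger inhibitor. There compound 1 `CC(C)(C)C[C@H]1O[C@H](COCc2ccccc2)[C@@H](OCc2ccccc2)[C@H](OCc2ccccc2)[C@H]1O` gives 12100 nM, and compound 2 `CC(C)C[C@H]1O[C@H](COCc2ccccc2)[C@@H](OCc2ccccc2)[C@H](OCc2ccccc2)[C@H]1O` gives 13900 nM. These two values lie within the scatter of each other, so the numbers cannot separate compound 2 from compound 1.

Compound 3 `CCC[C@H]1O[C@H](COCc2ccccc2)[C@@H](OCc2ccccc2)[C@H](OCc2ccccc2)[C@H]1O` differs from compound 2 in one place: hydrogen in place of methyl on a saturated chain carbon bound to two saturated chain carbons. Here hydrogen stands in place of methyl on a saturated chain carbon bound to two saturated chain carbons, which turns isobutyl into propyl.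

For the measured compounds named here, one measured step bears on this, a like swap on a saturated chain carbon bound to three saturated chain carbons: a 1.1-fold higher number from compound 1 to compound 2 (0.06 log units; within the scatter). That step stayed within the scatter, although it sits on a different carbon, so no change beyond the scatter is expected in this assay. The expected step is a 1.0-fold higher number from compound 2 to compound 3 (0.00 log units; within the scatter). The estimate for compound 3 is 14000 nM, with an expected range of 7000 nM to 28000 nM.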

Compound 3, half-maximal inhibitory concentration: 28200 nM
Estimate against measurement, compound 3: 2.0-fold (0.30 log units) below; measured number outside the range, above it.
By their numbers in this assay, from the lowest: compounds 1 and 2 (each within the scatter of the next); then compound 3.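

In this assay, for the compounds shown here, this is the first change in the side chain that moves the number beyond the scatter: a 2.0-fold higher number from compound 2 to compound 3 (0.31 log units; beyond the scatter), a modest loss of activity. Taking a methyl from a saturated chain carbon bound to two saturated chain carbons therefore registers here, whereas the like swap on a carbon bound to three did not, and the gap from the bulkiest chain is similar, with a 2.3-fold higher number from compound 1 to compound 3 (0.37 log units; beyond the scatter). Nothing available here explains why the two swaps differ.

The three compounds show only branched chains and propyl on one shared core, so they leave open whether the number would keep rising with a shorter chain or fall again with a longer one such as pentyl. As far as these compounds go, how a chain ending in an amine or a carboxylic acid would behave at this position also remains unknown.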